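This account rests on a few compounds, and the source may have more. Where it says the series, first, only, none or still open, it means among the compounds named here.

Compound 1 `O=C1COc2ccc(-c3cccc(NS(=O)(=O)c4ccc(F)cc4)c3)cc2N1c1ccc(F)cc1` — in a functional assay on A549 cells (Homo sapiens) for antiproliferative activity, read by MTT assay, with a stated time of 72 h (on this read-out higher numbers stand for weaker inhibition and lower numbers for stronger inhibition), compound 1 gives > 40000 nM, a limit of the assay.
Compound 2 `COc1cccc(N2C(=O)COc3ccc(-c4cccc(NS(=O)(=O)c5ccc(F)cc5)c4)cc32)c1` — in this assay compound 2 gives > 40000 nM, also a limit of the assay.

Compound 2 stands only at a limit in this assay. For the measured compounds named here, the one measured step, a step that the two limits leave unreadable from compound 1 to compound 2, is the limit of > 40000 nM in this assay, at which 2 of the 2 values shown sit, and so is not readable. Compound 3 `O=C1COc2ccc(-c3cccc(NS(=O)(=O)c4ccc(F)cc4)c3)cc2N1` differs from compound 2 by hydrogen in place of 3-methoxyphenyl on an amide-type nitrogen in a ring. Going by the values given here, no measured step bears on this change, and both measured values are limits, so no direction can be read; the expectation is therefore a step of no readable size, a number no higher from compound 2 to compound 3 (the limit leaves the size open). Compound 3 is estimated at 40000 nM, expected between 10000 nM and 100000 nM, most likely reported again as a limit.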

Compound 3, half-maximal inhibitory concentration: 32100 nM
Beside the measured number, compound 3's estimate is 1.2-fold (0.10 log units) above it; measured number inside the range.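

For the compounds shown here, with hydrogen on the amide-type nitrogen in a ring, compound 3 gives the first value in this assay that is not a limit, 32100 nM. Hydrogen in place of 3-methoxyphenyl reads as an at least 1.2-fold lower number from compound 2 to compound 3 (0.09 log units; that floor lies within the scatter), and hydrogen in place of 4-fluorophenyl reads as an at least 1.2-fold lower number from compound 1 to compound 3 (0.09 log units; that floor lies within the scatter). The full size of both steps stays open because compound 1 and compound 2 stand at a limit: the limit of > 40000 nM in this assay, at which 2 of the 3 values shown sit.

The step between the two aryl groups cannot be read. Open, going by these compounds, is what a methyl group, a longer alkyl chain or a chain ending in an amine would give on this nitrogen.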